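Predicting Clearance After One More Ring Swap

The source may report more compounds than this note shows. Statements on the series, on what has been measured and on what is new or still open speak of the compounds shown alone.

In an ADME assay (liver) for metabolic stability, with Liver microsome (Rattus norvegicus) as the target, using microsomes and NADPH, with a stated time of 30 min, tested at 1 uM (on this read-out lower numbers stand for slow clearance and higher numbers for fast clearance), compound 3 `Nc1ccc(S(=O)(=O)N2CCN(c3ncc(C(O)(C(F)(F)F)C(F)(F)F)cc3-c3ccc4c(c3)CC(=O)N4)CC2)cn1` gives 119 mL.min-1.g-1, which lies within the scatter of compound 1 `Nc1ccc(S(=O)(=O)N2CCN(c3ncc(C(O)(C(F)(F)F)C(F)(F)F)cc3C#CCO)CC2)cn1` at 65 mL.min-1.g-1 and of compound 2 `Cc1ccc(-c2cc(C(O)(C(F)(F)F)C(F)(F)F)cnc2N2CCN(S(=O)(=O)c3ccc(N)nc3)CC2)cn1` at 182 mL.min-1.g-1. Compound 4 `Nc1ccc(S(=O)(=O)N2CCN(c3ncc(C(O)(C(F)(F)F)C(F)(F)F)cc3-c3cc4ccccc4s3)CC2)cn1` brings in 1-benzothiophen-2-yl at the same aromatic carbon: a group of 9 heavy atoms (8 carbon, 1 sulfur; one five-membered aromatic ring with 1 hetero atom, one six-membered aromatic ring of carbon only) in place of a group of 10 heavy atoms (8 carbon, 1 nitrogen, 1 oxygen; one five-membered non-aromatic ring with 1 hetero atom, one six-membered aromatic ring of carbon only), on an aromatic carbon. Replacing the 3-hydroxyprop-1-yn-1-yl group of compound 1 gave a 2.8-fold higher number from compound 1 to compound 2 (0.45 log units; beyond the scatter) and a 1.8-fold higher number from compound 1 to compound 3 (0.26 log units; within the scatter). The closest parallel exchanges one ring group for another, and it gave a 1.5-fold lower number from compound 2 to compound 3 (0.18 log units; within the scatter). On that single precedent, no step beyond the scatter is expected in this assay. The expected step is a 1.4-fold higher number from compound 3 to compound 4 (0.15 log units; within the scatter). For compound 4 the estimated value is 170 mL.min-1.g-1, with an expected range of 80 mL.min-1.g-1 to 340 mL.min-1.g-1.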

Compound 4, intrinsic clearance in microsomes: 315 mL.min-1.g-1
Beside the measured number, compound 4's estimate is 1.9-fold (0.27 log units) below it, and the stated range covers the measured number.
By their numbers in this assay, from the lowest: compounds 1, 3, 2 and 4 (each within the scatter of the next, the first and the last beyond it).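

In this assay, 1-benzothiophen-2-yl in place of the previous two-ring group gives a 2.6-fold higher number from compound 3 to compound 4 (0.42 log units; beyond the scatter), so at this aromatic carbon, ortho to a large group, exchanging one ring group for another can produce a step beyond the scatter. The exchange for 6-methylpyridin-3-yl gives a 1.7-fold higher number from compound 2 to compound 4 (0.24 log units; within the scatter). The exchange for 3-hydroxyprop-1-yn-1-yl gives a 4.8-fold higher number from compound 1 to compound 4 (0.69 log units; beyond the scatter), the largest step among these compounds.

No measurement shown explains these steps. Going by these compounds, whether an amine or a carboxylic acid on the 1-benzothiophen-2-yl group would lower the clearance remains open.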